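The compounds below may be only part of what the source reports. "The series", "measured", "known", "first", "only" and "open" are said of these compounds alone.

In a functional assay on SK-OV-3 cells (Homo sapiens) for inhibition, read by CCK-8 assay, with a stated time of 70 h (on this read-out lower numbers stand for stronger inhibition and higher numbers for weaker inhibition), compound 3 `Nc1ccc(COc2ccc(OCCOCCNC3CCCC3)cc2)cc1` gives 31700 nM, level within the scatter with compound 1 `c1ccc(COc2ccc(OCCOCCNC3CCCC3)cc2)cc1` at 24800 nM. Compound 2 `Clc1ccc(COc2ccc(OCCOCCNC3CCCC3)cc2)cc1` gives 7670 nM, and the gap to compound 3 is a 4.1-fold higher number from compound 2 to compound 3 (0.62 log units; beyond the scatter). Compound 4 `c1ccc(COc2ccc(COc3ccc(OCCOCCNC4CCCC4)cc3)cc2)cc1` has benzyloxy in place of amino on an aromatic carbon, para to a large group: benzyloxy in place of amino on an aromatic carbon. Two measured changes bear on this: chloro gave a 3.2-fold lower number from compound 1 to compound 2 (0.51 log units; beyond the scatter), and amino gave a 1.3-fold higher number from compound 1 to compound 3 (0.11 log units; within the scatter). Among the compounds with values here, no measured compound carries benzyloxy, so the expectation is loose: a modest move to a lower number in this assay, close in size to the chloro step. The estimated step is a 3.5-fold lower number from compound 3 to compound 4 (0.55 log units; beyond the scatter). Compound 4 is estimated at 9000 nM, with an expected range of 2500 nM to 30000 nM.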

Compound 4, half-maximal inhibitory concentration: 10000 nM
For compound 4 the middle estimate is 1.1-fold (0.05 log units) below the measured one; the range from low to high includes it.
By their numbers in this assay, from the lowest: compounds 2 and 4 (each within the scatter of the next); then compounds 1 and 3 (each within the scatter of the next).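

In this assay, benzyloxy at this aromatic carbon, para to a large group, shows that the position accepts a far larger substituent than chloro or amino and still gives a lower number than hydrogen (a 2.5-fold lower number from compound 1 to compound 4 (0.39 log units; beyond the scatter)) or amino (a 3.2-fold lower number from compound 3 to compound 4 (0.50 log units; beyond the scatter)). Chloro and benzyloxy stay level within the scatter (a 1.3-fold higher number from compound 2 to compound 4 (0.12 log units; within the scatter)), so added size brings no gain over chloro here. No evidence explains either step.

As far as these compounds go, whether methoxy, phenoxy or a carboxylic acid at this carbon would match benzyloxy remains open. So does the effect of a longer chain between the two aromatic rings.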